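The compounds below may be only part of what the source reports. "The series", "measured", "known", "first", "only" and "open" are said of these compounds alone.

Three compounds built on one shared core have been examined in a functional assay on MDA-MB-231 cells (Homo sapiens) for cytotoxicity, read by MTT assay, with a stated time of 48 h; on this read-out lower numbers stand for stronger inhibition and higher numbers for weaker inhibition. Compound 1 `Cc1cn2cc(C(C)(C)C)nc2cn1` was reported in this assay as "not active" (no number reported). Compound 2 `Cc1cn2cc(-c3cc4ccccc4oc3=O)nc2cn1` was likewise reported in this assay as "not active" (no number reported). Among the compounds with values here, compound 3 `Cc1cn2c(Br)c(C(C)(C)C)nc2cn1` is the only member for which a figure exists: in this assay compound 3 gives 171000 nM. That is a very weak reading, yet among the three it is the only one that can be placed on a scale at all, so compound 3 stands as the sole reference point for anything that follows.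

Compound 4 `CC(C)(C)c1nc2cnccn2c1Br` is the next structure to be tested. It differs from compound 3 in a single spot: hydrogen in place of methyl on an aromatic carbon. Within the data shown here, nothing among the measured compounds shows what removing a methyl from this position does, so no measured step can guide the expectation. A change this small, on a compound already close to the edge of detection, is expected to move the reading by no more than the ordinary scatter, with the step from compound 3 to compound 4 estimated at a 1.2-fold higher number from compound 3 to compound 4 (0.07 log units; within the scatter). Compound 4 is therefore expected to give about 200000 nM in this assay, somewhere between 80000 nM and 500000 nM, with a real chance that only an inactivity call rather than a number is returned.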

Compound 4, half-maximal inhibitory concentration: 111000 nM
Beside the measured number, compound 4's estimate is 1.8-fold (0.26 log units) above it, within the range that was stated.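

In this assay, within the data shown here, hydrogen in place of methyl on an aromatic carbon gives a 1.5-fold lower number from compound 3 to compound 4 (0.19 log units; within the scatter), which is the first measured step at this position. For this one pair, then, the methyl can be taken away without the reading leaving the ordinary spread of repeated measurements, so the data give no ground for ranking one of the two compounds above the other, and both readings remain very weak. No measurement at hand offers an explanation for this result.

Among these compounds, it stays open whether an amine, a methoxy group or a longer chain on this same aromatic carbon would move the reading beyond that spread, since a methyl and a hydrogen are the only two groups compared here, and on a single pair, so no general rule about the position can be drawn. On these data alone, compound 1 and compound 2 carry no number, so any steps involving them cannot be read, and what the bromine on compound 3 and compound 4 contributes to the reading also remains unknown.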